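Methoxy for chloro on an oxime-bearing styryl pair

This account rests on a few compounds, and the source may have more. Where it says the series, first, only, none or still open, it means among the compounds named here.

Of the compounds shown here, two of one shared core have been measured in an ADME assay on cells (Mus musculus, strain Balb/c) for cytotoxicity, read by MTT assay, with a stated time of 48 h; on this read-out lower numbers stand for higher toxicity in this test and higher numbers for lower toxicity in this test. Compound 1 `COc1ccc(/C=C/C(=N\O)c2ccc(OC)cc2)cc1` gives 2170000 nM in this assay, whereas compound 2 `Cc1ccc(C(/C=C/c2ccc(Cl)cc2)=N/O)cc1` gives 21300 nM. Compound 2 therefore stands at the lowest of the two numbers, and compound 1 lies higher by a gap beyond the scatter. The next compound, compound 3 `COc1ccc(/C=C/C(=N\O)c2ccc(C)cc2)cc1`, differs from compound 2 in one place: methoxy in place of chloro on an aromatic carbon. Among the measured compounds shown here, no step between two measured compounds isolates this change, so its size cannot be read from the data. Since compound 1 carries methoxy groups and gives 2170000 nM, the account expects a large step upward from compound 2 to compound 3, of about a 14-fold higher number from compound 2 to compound 3 (1.15 log units; beyond the scatter), in this assay. Compound 3 is accordingly estimated at 300000 nM in this assay, within a range from 50000 nM to 2000000 nM.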

Compound 3, half-maximal cytotoxic concentration: 117000 nM
Compound 3: the middle estimate sits 2.6-fold (0.41 log units) above what was measured; the measured number falls inside the stated range.
By their numbers in this assay, from the lowest: compound 2; then compound 3; then compound 1.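

In this assay the aromatic carbon para to a large group proves sensitive to what it carries: methoxy in place of chloro gives a 5.5-fold higher number from compound 2 to compound 3 (0.74 log units; beyond the scatter) and so separates the two groups by more than the scatter. Methyl in place of methoxy, a change at another place in the shared core, gives a 19-fold lower number from compound 1 to compound 3 (1.27 log units; beyond the scatter) and shows that this second site also moves the number, here by a large step. Nothing measured here accounts for either step.

The compounds shown leave open how an amine or a carboxylic acid on the aromatic carbon para to a large group would stand in this assay. They also leave open whether methoxy in place of chloro gives a similar step when an ethyl group replaces the methyl elsewhere on the core.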